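The compounds below may be only part of what the source reports. "The series", "measured", "known", "first", "only" and "open" are said of these compounds alone.

Measured in a functional assay on Raji cells (Homo sapiens) for antiproliferative activity, read by MTT assay, with a stated time of 48 h; on this read-out higher numbers stand for weaker inhibition and lower numbers for stronger inhibition:
Compound 1 `Cn1c(N)c(-c2nc3ccccc3[nH]2)c2nc(C#N)c(C#N)nc21`: > 50000 nM, a limit
Compound 2 `CCn1c(N)c(-c2nc3ccccc3[nH]2)c2nc(C#N)c(C#N)nc21`: > 50000 nM, a limit

Compound 2 therefore has no numerical value in this assay, and its position is defined only by this limit. The same is true of compound 1, as the limit of > 50000 nM in this assay, at which 2 of the 2 values shown sit, shows. Compound 3 `CN(C)CCn1c(N)c(-c2nc3ccccc3[nH]2)c2nc(C#N)c(C#N)nc21` differs from compound 2 as follows: dimethylamino in place of hydrogen on a saturated chain carbon, two bonds along the chain from an aromatic nitrogen. In other words, ethyl becomes 2-(dimethylamino)ethyl. Among the measured compounds shown here, the only measured step bearing on this change is a step that the two limits leave unreadable from compound 1 to compound 2, so it offers no size to carry forward. It also concerns a methyl, not a dimethylamino, group. No firm size or direction can therefore be expected, although only stronger inhibition could appear as a readable change, and compound 3 may well remain at the limit. The expected step is an at least 1.6-fold lower number from compound 2 to compound 3 (0.22 log units; that floor lies within the scatter). For compound 3, the estimated value is 30000 nM, with an estimated range of 5000 nM to 100000 nM.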

Compound 3, half-maximal inhibitory concentration: 8320 nM
Estimate against measurement, compound 3: 3.6-fold (0.56 log units) above, within the range that was stated.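

In this assay, compound 3 is the only one of the three compounds shown to give a number rather than a limit, so a change on this chain can now be read: an at least 6.0-fold lower number from compound 2 to compound 3 (0.77 log units; beyond the scatter), and an at least 6.0-fold lower number from compound 1 to compound 3 (0.77 log units; beyond the scatter). The change from methyl to ethyl could not be read, whereas dimethylamino on the saturated chain carbon, two bonds along the chain from an aromatic nitrogen, gives a step beyond the scatter. Both steps are floors and their full size is unknown, since each starts from a compound without a number: the limit of > 50000 nM in this assay, at which 2 of the 3 values shown sit.

The compounds shown do not tell whether the amine nitrogen itself matters or whether a 2-methoxyethyl chain of similar length would serve as well. Also open, on these data alone, is how a primary amine, a morpholine or a longer chain carrying the dimethylamino group would compare.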